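A few compounds are considered here, and "the series" means these few. Any claim that something is new, unique, unknown or untested is made for them only; others in the source may bear on it.

In a functional assay on the whole organism (Tail, strain ICR) with Mus musculus as the target, in the tail flick test, with a stated time of 60 min, at a dose of 25 umol/kg by the oral route (on this read-out lower numbers stand for a weaker effect and higher numbers for a stronger effect at the one dose given), compound 1, whose structure is `C[C@H](NC(=O)CN(c1ncnc2c1ncn2C1CCCCO1)C1CC1)C(=O)OCc1ccccc1`, gives 53%. That is the highest of the three numbers available: compound 2, with the structure `O=C(O)C[C@H](NC(=O)CN(c1nc(Cl)nc2[nH]cnc12)C1CC1)C(=O)O`, gives 38.9% in this assay, and compound 3, with the structure `NC(=O)C[C@H](NC(=O)CN(c1nc(Cl)nc2[nH]cnc12)C1CC1)C(=O)OCc1ccccc1`, gives 36.4%. Both of these lie beyond the usual scatter below the number for compound 1, so compound 1 stands clearly above the other two measured compounds on this read-out.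

Compound 4, with the structure `O=C(CN(c1ncnc2c1ncn2C1CCCCO1)C1CC1)N[C@@H](CC(=O)OCc1ccccc1)C(=O)OCc1ccccc1`, has not yet been measured in this assay. It differs from compound 1 in one place: benzyloxycarbonyl in place of hydrogen on a saturated chain carbon, two bonds along the chain from an amide-type nitrogen and a carbonyl carbon. Going by the values given here, no pair of measured compounds differs from one another in just this way, so the size of the step can only be expected, not read from the data. Compounds 2 and 3 each carry a larger group on the same kind of chain carbon than compound 1 does, and both give lower numbers than compound 1, but they also differ from compound 1 elsewhere, so their values show no more than that.

Compound 4 is therefore expected to come in somewhat below compound 1, with an estimated step of a number 13 percentage points lower from compound 1 to compound 4 (beyond the scatter) in this assay, though a result within the scatter of compound 1 would not be surprising. The estimated value for compound 4 is 40%, with a range from 20% to 60%.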

Compound 4, a percentage reported as activity, at one dose (the size of the read-out at that dose, not a potency): 38.2%
Compound 4: middle estimate off by 1.8 percentage points, on the high side; the range from low to high includes it.
By their numbers in this assay, from the lowest: compounds 3, 4 and 2 (each within the scatter of the next); then compound 1.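

In this assay, going by these compounds alone, the change from hydrogen to benzyloxycarbonyl on a saturated chain carbon, two bonds along the chain from an amide-type nitrogen and a carbonyl carbon, gives a number 14.8 percentage points lower from compound 1 to compound 4 (beyond the scatter) and is the first reading of a single change. Cut one bond further out, the same difference reads methyl to (benzyloxycarbonyl)methyl, which shows that this position does not tolerate every enlargement of the methyl group of compound 1 without a loss at the one dose given, with the rest of the molecule unchanged. Nothing measured here accounts for the drop, and the step stands as an observation only.

The change brings in the ester and the aromatic ring together, and the compounds shown leave open which of these parts, or the added length alone, carries the step. Also open, as far as these compounds go, is whether an ethyl group, a carboxylic acid or an amine on a chain at this same carbon would give a step of similar size, or none beyond the scatter.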